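The compounds below may be only part of what the source reports. "The series", "measured", "known", "first", "only" and "open" are said of these compounds alone.

Of the compounds shown here, three sharing one core have been measured in a functional assay for inhibition, with Homo sapiens as the target (on this read-out higher numbers stand for weaker inhibition and lower numbers for stronger inhibition), so far. Compound 1 `Cc1cccc(Nc2nccc(-c3cc(C)oc3C)n2)c1` gives 28500 nM in this assay, compound 2 `Cc1cccc(Nc2nccc(-c3ccco3)n2)c1` gives 2100 nM in this assay, and compound 3 `Cc1cccc(Nc2nccc(-c3ccccn3)n2)c1` gives 700 nM in this assay, which is the lowest of the three numbers. Every step between them lies beyond the scatter: a 14-fold lower number from compound 1 to compound 2 (1.13 log units; beyond the scatter) is large, a 41-fold lower number from compound 1 to compound 3 (1.61 log units; beyond the scatter) is large, and a 3.0-fold lower number from compound 2 to compound 3 (0.48 log units; beyond the scatter) is modest. Compound 3 therefore stands clearly apart from both others, and the ring attached to the shared core evidently matters.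

Among the measured compounds shown here, compound 4 `Cc1cccc(Nc2nccc(-c3ccncc3)n2)c1` is the next step, and pyridin-4-yl in place of pyridin-2-yl on an aromatic carbon is the only difference from compound 3; the atoms are the same and only their joining changes. For the measured compounds named here, no measured step swaps one pyridyl ring for another, so the guide is indirect. The step of a 3.0-fold lower number from compound 2 to compound 3 (0.48 log units; beyond the scatter) shows that exchanging one aromatic ring for another can shift this assay by a modest amount, while the larger steps starting from compound 1 involve the ring named 2,5-dimethylfuran-3-yl and are less comparable. A modest change is expected, more likely toward a higher number because compound 3 at 700 nM is already the lowest number seen, giving a 2.1-fold higher number from compound 3 to compound 4 (0.33 log units; beyond the scatter) as the estimated step. Compound 4 is estimated at 1500 nM in this assay, within a range from 400 nM to 6000 nM in this assay.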

Compound 4, half-maximal inhibitory concentration: 8800 nM
For compound 4 the middle estimate is 5.9-fold (0.77 log units) below the measured one; the measured number lies above the stated range.
By their numbers in this assay, from the lowest: compound 3; then compound 2; then compound 4; then compound 1.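

Even with the atoms unchanged, the way the pyridine ring is joined matters at this position on the shared core: in this assay, pyridin-4-yl in place of pyridin-2-yl gives a large change (a 13-fold higher number from compound 3 to compound 4 (1.10 log units; beyond the scatter)). The kind of ring alone therefore does not set the number, since pyridin-2-yl gave a lower number than furan-2-yl (a 3.0-fold lower number from compound 2 to compound 3 (0.48 log units; beyond the scatter)), whereas pyridin-4-yl gives a higher one (a 4.2-fold higher number from compound 2 to compound 4 (0.62 log units; beyond the scatter)), though it still improves on 2,5-dimethylfuran-3-yl (a 3.2-fold lower number from compound 1 to compound 4 (0.51 log units; beyond the scatter)). Nothing available here explains why the two pyridine rings differ so much.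

The compounds shown leave open whether pyridin-3-yl, the remaining way of joining this ring, would sit nearer compound 3 or compound 4. They also do not tell whether a plain phenyl ring, or a pyridin-2-yl ring carrying a methyl group or an amine, would keep or lose the low number of compound 3.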